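Adding a methyl to the aniline ring of a benzylidene cyclohexanone

The source may hold more compounds than are shown below. What is called first, only, known or untested is meant among the compounds shown, and "the series" means these compounds.

Two compounds have been run in a functional assay on the whole organism (strain Wistar) for inhibition, with Rattus norvegicus as the target, read by paw edema, with stated times of 1 h and 3 h, at a dose of 200 mg/kg by the oral route; a higher number here means more inhibition at the dose given (going by the name of the read-out), a lower number less inhibition. Compound 1 `Cc1ccc(N(C)CC2CCC/C(=C\c3ccccc3)C2=O)cc1` gives 25.5% in this assay. Compound 2 `Cc1ccc(/C=C2\CCCC(CN(C)c3ccccc3)C2=O)cc1` gives 44.7% in this assay. Of the two numbers, compound 2 holds the higher one, and the nearest, that of compound 1, lies a number of percentage points below it that is beyond the usual scatter. Within the data shown here, since the two compounds differ from each other in more than one place, no single step between them is on record, and the pair shows nothing more than these two values.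

Compound 3 `Cc1ccc(/C=C2\CCCC(CN(C)c3ccc(C)cc3)C2=O)cc1` has not yet been measured in this assay. It differs from compound 2 in one place: methyl in place of hydrogen on an aromatic carbon. Among the measured compounds shown here, no measured step of this kind is at hand, so the effect of the change can only be estimated. The step from compound 2 to compound 3 is expected to be small, with no clear direction and likely within the scatter, a number 2.7 percentage points lower from compound 2 to compound 3 (within the scatter). On that basis, compound 3 is expected to give about 42% in this assay, with a range from 26% to 58%.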

Compound 3, a percentage reported as inhibition, in the whole organism at one dose (the size of the read-out at that dose, not a potency): 38.3%
Estimate against measurement, compound 3: 3.7 percentage points above, within the range that was stated.
By their numbers in this assay, from the lowest: compound 1; then compounds 3 and 2 (each within the scatter of the next).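

Among these compounds, the phenyl to 4-methylphenyl change, with the methyl on the aniline ring para to a large group, gives the first reading at this position in this assay: a number 6.4 percentage points lower from compound 2 to compound 3 (within the scatter), so a methyl here leaves the inhibition indistinguishable from that of the compound without it. The same kind of change on the other aromatic ring reads a number 12.8 percentage points higher from compound 1 to compound 3 (beyond the scatter), and of these two steps only this one lies beyond the scatter, so with a methyl already on the aniline ring, the methyl on the other ring is the one that registers at this dose. Nothing available explains why the two places differ.

On these data alone, whether the aniline position stays this undemanding for groups other than methyl remains open, for example with a methoxy group, a chlorine atom or a longer chain such as ethyl. As far as these compounds go, it is also open how the methyl on the other ring would read with no methyl on the aniline ring, and since all of these readings come from one dose, they say nothing about potency.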